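Moving a trifluoromethyl group on a phenyl ether

The source may hold more compounds than are shown below. What is called first, only, known or untested is meant among the compounds shown, and "the series" means these compounds.

Four compounds share one core: a hydroxy-bearing saturated carbon carrying an amide to a phenyl ring that holds a pentafluorosulfanyl group, and an ether link to a second phenyl ring that holds a trifluoromethyl group. Compound 1 `CC(O)(COc1cccc(C(F)(F)F)c1)C(=O)Nc1ccc(S(F)(F)(F)(F)F)cc1` and compound 2 `CC(O)(COc1ccccc1C(F)(F)F)C(=O)Nc1ccc(S(F)(F)(F)(F)F)cc1` place the pentafluorosulfanyl group in one way, compound 3 `CC(O)(COc1cccc(C(F)(F)F)c1)C(=O)Nc1cccc(S(F)(F)(F)(F)F)c1` and compound 4 `CC(O)(COc1ccccc1C(F)(F)F)C(=O)Nc1cccc(S(F)(F)(F)(F)F)c1` in another; the difference between the two cores is not broken down here.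

In a functional assay on CWR22R cells (Homo sapiens) for antiproliferative activity, read by propidium iodide staining, with a stated time of 96 h (a higher number here means a weaker inhibitor, a lower number a stronger inhibitor), compound 1 gives 14600 nM, and compound 2 gives 1400 nM. The change between them is 2-(trifluoromethyl)phenyl in place of 3-(trifluoromethyl)phenyl on an oxygen on a saturated carbon, and it made the number fall sharply: a 10-fold lower number from compound 1 to compound 2 (1.02 log units; beyond the scatter).

Compound 3 gives 28900 nM in this assay. Against compound 1 this is a gap within the usual scatter, so the two read as alike; against compound 2 the gap is clearly larger.

Compound 4 is not yet measured. For the measured compounds named here, it differs from compound 3 by 2-(trifluoromethyl)phenyl in place of 3-(trifluoromethyl)phenyl on an oxygen on a saturated carbon, the same change, made at the same place, as the one from compound 1 to compound 2. If the change behaves as it did there, compound 4 is expected to improve on compound 3 by about a 9.6-fold lower number from compound 3 to compound 4 (0.98 log units; beyond the scatter), a step resting on a 10-fold lower number from compound 1 to compound 2 (1.02 log units; beyond the scatter). On that basis compound 4 is estimated to give 3000 nM in this assay, between 1000 nM and 9000 nM.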

Compound 4, half-maximal inhibitory concentration: 34900 nM
Beside the measured number, compound 4's estimate is 12-fold (1.07 log units) below it; measured number outside the range, above it.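

On the core of compound 3, the change did not repeat what it did on the core of compound 1: in this assay the step reads a 1.2-fold higher number from compound 3 to compound 4 (0.08 log units; within the scatter), so compound 3 and compound 4 read as alike. Set side by side, the two results show that one change, made at the same place, gave clearly different outcomes on the two cores: the same change on two cores in this assay, a 10-fold lower number (1.02 log units; beyond the scatter) from compound 1 to compound 2 and a 1.2-fold higher number (0.08 log units; within the scatter) from compound 3 to compound 4, 13-fold (1.10 log units) apart, beyond the scatter of two such steps

This shows that the gain seen on the core of compound 1 cannot be assumed to carry over to the core of compound 3 in this series, and that a step measured on one core is a weak guide to the same step on another. For the compounds shown here, it does not show why the two cores differ, and with only one pair on each core it gives no rule for other cores or other changes.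

The compounds shown leave open whether a different group in place of trifluoromethyl on the phenyl ether, such as a nitrile or a chlorine atom, would also depend on the core. They also leave open what a longer chain in place of the methyl group on the hydroxy-bearing carbon would do on either core.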